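This account rests on a few compounds, and the source may have more. Where it says the series, first, only, none or still open, it means among the compounds named here.

Compound 1 `CCN(CC)S(=O)(=O)c1ccc(S(=O)(=O)N2CCC[C@@H](C(=O)NC3CN(C(=O)C4CC4)C3)C2)cc1` — 2800 nM
Compound 2 `CCOC(=O)[C@@H]1CCCN(S(=O)(=O)c2ccc(S(=N)(=O)N(CC)CC)cc2)C1` — 2600 nM
Compound 3 `CCN1CC(NC(=O)[C@@H]2CCCN(S(=O)(=O)c3ccc(S(=O)(=O)N(CC)CC)cc3)C2)C1` — only a limit, > 30000 nM
Compound 4 `CCCN(CC)S(=O)(=O)c1ccc(S(=O)(=O)N2CCC[C@@H](C(=O)OCC)C2)cc1` — not yet measured

Of the compounds shown here, three sharing the same core have been measured in a functional assay on MIA PaCa-2 cells (Homo sapiens) for inhibition, read by MTT assay, with a stated time of 7 days; on this read-out higher numbers stand for weaker inhibition and lower numbers for stronger inhibition. Compound 2 gives the lowest number of the two proper values, with compound 1 sitting within the scatter of it, so no order between the two can be read. Compound 3 gives only a limit in this assay, (the limit of > 30000 nM in this assay, at which 1 of the 3 values shown sits). The one step that is shown, an at least 10-fold higher number from compound 1 to compound 3 (1.02 log units; beyond the scatter), concerns the amine nitrogen in a ring and not the position changed here.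

Compound 4 differs from compound 2 at one place: a group of 9 heavy atoms (5 carbon, 1 nitrogen, 2 oxygen, 1 sulfur; no ring) in place of a group of 8 heavy atoms (4 carbon, 2 nitrogen, 1 oxygen, 1 sulfur; no ring), on an aromatic carbon. Among the measured compounds shown here, no measured step bears on this position, so nothing in the data argues for a change beyond the scatter. Compound 4 is therefore expected to give about 2500 nM in this assay, between 900 nM and 7000 nM. The step from compound 2 to compound 4 is estimated as a 1.0-fold lower number from compound 2 to compound 4 (0.02 log units; within the scatter), within the scatter.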

Compound 4, half-maximal inhibitory concentration: 300 nM
Compound 4: the middle estimate sits 8.3-fold (0.92 log units) above what was measured; measured number below the stated range.
By their numbers in this assay, from the lowest: compound 4; then compounds 2 and 1 (each within the scatter of the next). At a limit, above all of these: compound 3.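

In this assay, the position on the aromatic carbon para to a large group proves sensitive: ethyl(propyl)sulfamoyl, in place of the group of 8 heavy atoms in compound 2, gives an 8.7-fold lower number from compound 2 to compound 4 (0.94 log units; beyond the scatter). Among the compounds shown here, the exchange replaces a group with 1 hydrogen-bond donor by one with 0 hydrogen-bond donors and also changes the alkyl substitution, while the count of 2 hydrogen-bond acceptors and the lack of net charge stay the same, so the single step cannot assign the gain to either difference. Nothing measured here accounts for the step.

Going by these compounds, how a diethylsulfamoyl, dipropylsulfamoyl or longer chain would behave on the ethyl ester core remains open. Also open, on these data alone, is whether ethyl(propyl)sulfamoyl has a similar effect when the ethyl ester is replaced by a carboxylic acid or an amide.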